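This account rests on a few compounds, and the source may have more. Where it says the series, first, only, none or still open, it means among the compounds named here.

Among the measured compounds shown here, compound 2 `CC1CCC(Sc2nc(C(F)(F)F)ccc2CNC(=O)C(C)c2ccc(NS(C)(=O)=O)c(F)c2)CC1` stands at 180 nM in an assay on CHO-K1 cells for antagonist activity at transient receptor potential cation channel subfamily V member 1 (Homo sapiens), read by FLIPR; on this read-out higher numbers stand for weaker inhibition and lower numbers for stronger inhibition; the only other number so far, compound 1 `CC(C(=O)NCc1ccc(C(F)(F)F)nc1SCCOc1ccccc1)c1ccc(NS(C)(=O)=O)c(F)c1` at 118 nM, lies within the scatter of it. Compound 3 `CC(C(=O)NCc1ccc(C(F)(F)F)nc1SCCc1ccccc1)c1ccc(NS(C)(=O)=O)c(F)c1` differs from compound 2 by phenethyl in place of 4-methylcyclohexyl on a sulfur. For the measured compounds named here, the one step measured at this sulfur, a 1.5-fold higher number from compound 1 to compound 2 (0.18 log units; within the scatter), exchanged the group on the sulfur without moving the number beyond the scatter, and phenethyl is close in makeup to the 2-phenoxyethyl of compound 1. No step beyond the scatter is therefore expected in this assay for compound 3, a 1.4-fold lower number from compound 2 to compound 3 (0.14 log units; within the scatter). Compound 3 is estimated at 130 nM, with a range from 60 nM to 300 nM.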

Compound 3, half-maximal inhibitory concentration: 111 nM
The estimate for compound 3 lay 1.2-fold (0.07 log units) above the measured number; low and high end bracket the measured number.
By their numbers in this assay, from the lowest: compounds 3, 1 and 2 (each within the scatter of the next).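

In this assay, an aromatic ring on the sulfur chain and a non-aromatic ring directly on the sulfur are not told apart: phenethyl in place of 4-methylcyclohexyl stays within the scatter (a 1.6-fold lower number from compound 2 to compound 3 (0.21 log units; within the scatter)). The chain itself also shows no response to phenyl in place of phenoxy (a 1.1-fold lower number from compound 1 to compound 3 (0.03 log units; within the scatter)), so the ether oxygen of compound 1 makes no readable difference here. No measurement on hand gives a reason for these numbers.

Going by these compounds, all three groups on the sulfur carry a six-membered ring, so it remains open whether a plain methyl would move the number beyond the scatter. The same holds for a chain ending in an amine or a carboxylic acid.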